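Adding a Second Methoxy to the Biphenyl Analogue

This account rests on a few compounds, and the source may have more. Where it says the series, first, only, none or still open, it means among the compounds named here.

Compound 1 `CCOC(=O)c1c(-c2cc(F)cc(OC)c2)[nH]c2cc(OC)ccc2c1=O` gives > 22000 nM in an ADME assay on HEK293 cells (Homo sapiens) for cytotoxicity, read by luminescence, with a stated time of 72 h (a higher number here means that more compound is needed for the effect, a lower number that less compound is needed), a limit of the assay.
Compound 2 `CCOC(=O)c1c(-c2cccc(-c3ccccc3)c2)[nH]c2cc(OC)ccc2c1=O` gives > 22000 nM in this assay, a limit of the assay.
Compound 3 `CCOC(=O)c1c(-c2cccc(F)c2)[nH]c2cc(OC)ccc2c1=O` gives > 22000 nM in this assay, a limit of the assay.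

All three measured compounds share one core and differ only in the group carried on the pendant aromatic ring. From compound 3 to compound 1 the change is methoxy in place of hydrogen on an aromatic carbon; the resulting step is a step that the two limits leave unreadable from compound 3 to compound 1, and it cannot be read because of the limit of > 22000 nM in this assay, at which 3 of the 3 values shown sit. From compound 3 to compound 2 the change is phenyl in place of fluoro on an aromatic carbon; the corresponding step, a step that the two limits leave unreadable from compound 2 to compound 3, is likewise hidden by the same limit.

Compound 4 `CCOC(=O)c1c(-c2cccc(-c3ccccc3)c2)[nH]c2cc(OC)c(OC)cc2c1=O` has not yet been measured. From compound 2 to compound 4 the change is methoxy in place of hydrogen on an aromatic carbon. This is the same kind of change as from compound 3 to compound 1, but the place differs: in compound 4 the methoxy enters a six-membered aromatic ring that is part of a fused system of two rings, ortho to a methoxy group, meta and para to a fused ring, whereas in compound 1 it enters a ring meta to a fluoro group and meta to a large group.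

Because every value shown sits at the limit of > 22000 nM in this assay, at which 3 of the 3 values shown sit, compound 4 is expected to stay at the limit as well, with an expected step that the limit leaves unreadable from compound 2 to compound 4. For compound 4 the estimate in this assay is 30000 nM, between 15000 nM and 100000 nM.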

Compound 4, half-maximal effective concentration: > 22000 nM
Compound 4: no number, only a limit; the forecaster's own chance of this, stated with the estimate: 85%; the middle value is on the limit's open side.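

In this assay compound 4 gives > 22000 nM as a limit of the assay. Among these compounds, no step from compound 2 to compound 4 can be read, because neither compound has a value beyond the limit: (the limit of > 22000 nM in this assay, at which 4 of the 4 values shown sit). The compounds shown leave open whether any of them reaches a half-maximal effect at a measurable concentration, and so whether the added methoxy changes the read-out at all.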